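A few compounds are considered here, and "the series" means these few. Any claim that something is new, unique, unknown or untested is made for them only; others in the source may bear on it.

Measured in a functional assay on PC-3 cells (Homo sapiens); a higher number here means a weaker inhibitor of growth, a lower number a stronger inhibitor of growth:
compound 1, `O=S(=O)(/C=C/c1ccc(Cl)cc1Cl)Cc1ccc(Nc2ncnc3ccc(Br)cc23)cc1`: 4000 nM
compound 2, `O=S(=O)(/C=C/c1ccc(C(F)(F)F)cc1F)Cc1ccc(Nc2ncnc3ccc(Br)cc23)cc1`: 58000 nM
compound 3, `O=S(=O)(/C=C/c1ccc(Cl)cc1Cl)Cc1ccc(Nc2ncnc3cc(Cl)ccc23)cc1`: 38000 nM

Compound 1 and compound 2 share one core and differ at a single place, (2-fluoro-4-(trifluoromethyl)phenyl in place of 2,4-dichlorophenyl on a double-bonded chain carbon bound to a double-bonded chain carbon). Among the compounds with values here, that change gives a 15-fold higher number from compound 1 to compound 2 (1.16 log units; beyond the scatter), the one large step measured so far.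

Compound 3 carries the 2,4-dichlorophenyl group of compound 1 on a second core; the difference between the two cores is not broken down here. In this assay compound 3 and compound 2 give numbers within the scatter of each other, so no order is read between them. Compound 3 gives a higher number than compound 1, and that gap lies beyond the scatter.

Compound 4, `O=S(=O)(/C=C/c1ccc(C(F)(F)F)cc1F)Cc1ccc(Nc2ncnc3cc(Cl)ccc23)cc1`, is not yet measured. It stands to compound 3 as compound 2 stands to compound 1: 2-fluoro-4-(trifluoromethyl)phenyl in place of 2,4-dichlorophenyl on a double-bonded chain carbon bound to a double-bonded chain carbon, the same change made on the second core. The step in this assay from compound 3 to compound 4 is expected to run in the same direction as the measured one, a higher number, though it is expected to be smaller than a 15-fold higher number from compound 1 to compound 2 (1.16 log units; beyond the scatter) because compound 3 already stands at 38000 nM. The estimated step is a 3.9-fold higher number from compound 3 to compound 4 (0.60 log units; beyond the scatter). A result reported only as a limit is a real possibility at this level.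

For compound 4 in this assay the estimate is 150000 nM, with a range from 45000 nM to 500000 nM.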

Compound 4, concentration for 50% growth inhibition: > 100000 nM
Compound 4: a limit, no number; the forecaster's own chance of this, stated with the estimate: 40%; the middle value lies beyond the limit too.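

In this assay compound 4 gives > 100000 nM, which is a limit of the assay and not a number. On the second core, 2-fluoro-4-(trifluoromethyl)phenyl in place of 2,4-dichlorophenyl gives an at least 2.6-fold higher number from compound 3 to compound 4 (0.42 log units; beyond the scatter), the same direction as on the core of compound 1, so in this one pair of cores the direction of the change carries over. Whether its size carries over cannot be said, and a single pair of cores shows no general rule for the series: the same change on two cores in this assay, a 15-fold higher number (1.16 log units; beyond the scatter) from compound 1 to compound 2 and an at least 2.6-fold higher number (0.42 log units; beyond the scatter) from compound 3 to compound 4; the limit leaves it open whether they differ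

From the compounds shown here alone, with 2-fluoro-4-(trifluoromethyl)phenyl held constant, the exchange of cores gives an at least 1.7-fold higher number from compound 2 to compound 4 (0.23 log units; that floor lies within the scatter), so whether the core matters with this group remains open. Also open, going by these compounds, is how the change behaves when the phenyl ring carries an amine or a carboxylic acid, or when a longer chain stands in place of the double-bonded chain.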